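The compounds below may be only part of what the source reports. "The series", "measured", "known", "first", "only" and "open" are said of these compounds alone.

Measured so far in a physicochemical assay for lipophilicity, read by HPLC (a lower number here means a more polar compound, a higher number a more lipophilic compound), are two compounds.

- compound 1 `CC(=O)NC[C@H]1CN(c2ccc(OC[C@@H](O)CNc3ccncc3)c(F)c2)C(=O)O1` gives -0.04
- compound 2 `CC(=O)NC[C@H]1CN(c2ccc(OC[C@H](O)CNC3CC3)c(F)c2)C(=O)O1` gives -0.1

Compound 2 (-0.1) lies within the scatter of compound 1, so the two cannot be told apart on this measurement.

Compound 3 `CC(=O)NC[C@H]1CN(c2ccc(OC[C@H](O)CNCCC(C)C)c(F)c2)C(=O)O1` keeps the shared core of compound 2 and places isopentyl in place of cyclopropyl on an amine nitrogen in the side chain.

Going by the values given here, the only measured step is a number 0.06 log units lower from compound 1 to compound 2 (within the scatter) and it exchanges one ring-bearing group for another, so it says little about a ring giving way to an open chain. The expectation therefore rests mainly on the greater carbon count of the entering group, which points to a higher number in this assay and a clear move. The expected change is a number 0.50 log units higher from compound 2 to compound 3 (beyond the scatter) and it is far from certain. Compound 3 is estimated at 0.4 and is expected to fall from 0 to 0.9 as its range.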

Compound 3, partition coefficient: 1.19
Compound 3: middle estimate off by 0.79 log units, on the low side; measured number above the stated range.
By their numbers in this assay, from the lowest: compounds 2 and 1 (each within the scatter of the next); then compound 3.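

In this assay, the substituent on this amine nitrogen proves able to shift the number strongly: isopentyl in place of cyclopropyl gives a number 1.29 log units higher from compound 2 to compound 3 (beyond the scatter), and isopentylamino in place of the pyridin-4-yl amino group gives a number 1.23 log units higher from compound 1 to compound 3 (beyond the scatter). Going by these compounds alone, the earlier comparison of two ring-bearing groups showed only a number 0.06 log units lower from compound 1 to compound 2 (within the scatter), so compound 3 is the first sign that this position has any real range in this measurement. Nothing shown here gives a reason for the size of these steps.

Compound 3 removes the ring and adds carbon in one change, so the contribution of each remains unresolved; a straight propyl chain on the same amine nitrogen would separate the two. On these data alone, it also remains open how the number responds to a longer chain, or to a chain carrying a carboxylic acid.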